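Aryl ether head changes on a shared diarylmethylpiperidine series

The source may report more compounds than this note shows. Statements on the series, on what has been measured and on what is new or still open speak of the compounds shown alone.

Three compounds with a shared core have numbers in a functional assay (aorta) with Oryctolagus cuniculus as the target; a higher number here means weaker binding, a lower number tighter binding. Compound 1 `COc1cc(C(C)=O)ccc1OCCCCN1CCC(C(c2ccc(F)cc2)c2ccc(F)cc2)CC1` gives 2.51 nM. Compound 2 `COC(=O)c1ccc(OCCCN2CCC(C(c3ccc(F)cc3)c3ccc(F)cc3)CC2)c(OC)c1` gives 1.26 nM. Compound 3 `N#Cc1ccc(OCCCN2CCC(C(c3ccc(F)cc3)c3ccc(F)cc3)CC2)cc1` gives 5.01 nM, the highest of the three: compound 1 sits within the scatter of it, while the step of a 4.0-fold higher number from compound 2 to compound 3 (0.60 log units; beyond the scatter) is the only one beyond the scatter. Compound 4 `Fc1ccc(C(c2ccc(F)cc2)C2CCN(CCCOc3cccc4ccccc34)CC2)cc1` differs from compound 3 by naphthalen-1-yl in place of 4-cyanophenyl on an oxygen on a saturated carbon. Among the measured compounds shown here, the sole measured step at this position, a 4.0-fold higher number from compound 2 to compound 3 (0.60 log units; beyond the scatter), shows the aryl head can move the number modestly, but no measured compound carries naphthalen-1-yl, so direction is unsure. Compound 4 is expected near compound 3, a step of a 1.4-fold lower number from compound 3 to compound 4 (0.16 log units; within the scatter) within the scatter. The estimate for compound 4 is 3.5 nM, range 1 nM to 12 nM.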

Compound 4, dissociation constant: 5.01 nM
Estimate against measurement, compound 4: 1.4-fold (0.16 log units) below; low and high end bracket the measured number.
By their numbers in this assay, from the lowest: compounds 2, 1, 3 and 4 (each within the scatter of the next, the first and the last beyond it).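

Replacing 4-cyanophenyl with naphthalen-1-yl on the oxygen leaves this assay flat (no change at the digits printed from compound 3 to compound 4 (within the scatter)), so the nitrile can go and a second aromatic ring of carbon can enter with no readable shift. Compound 2 stays apart from this new head too (a 4.0-fold higher number from compound 2 to compound 4 (0.60 log units; beyond the scatter)), matching its step to compound 3 in size. Nothing available explains this flatness.

Still open, as far as these compounds go, is whether an amine or a carboxylic acid on the aryl head would leave this level. The methoxy and methoxycarbonyl groups of compound 2 also remain unseparated, so neither can be tied to its lower number.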